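Methoxy in Place of tert-Butyl: Compound 3 to Compound 4

The source may report more compounds than this note shows. Statements on the series, on what has been measured and on what is new or still open speak of the compounds shown alone.

Compound 3 `CN1CCN(CC(=O)NC2(c3ccc(C(C)(C)C)cc3)C(=O)Nc3cc(Cl)c(Cl)cc32)CC1` carries a tert-butyl group on its phenyl ring. In an in vitro functional assay on CHO-CREluc cells for antagonist activity at growth hormone secretagogue receptor type 1 (Homo sapiens), read by a luciferase reporter, with a stated time of 4 h (a lower number here means a stronger inhibitor, a higher number a weaker inhibitor), compound 3 gives 1470 nM, the highest of the two numbers measured here. Its nearest neighbour is compound 2 `COc1ccc(C2(NC(=O)CN3CCN(C)CC3)C(=O)Nc3cc(Cl)c(C)cc32)cc1`, which bears methoxy on the phenyl ring together with a different core and gives 525 nM in this assay. Compound 1 `CN1CCN(CC(=O)NC2(c3ccc(Cl)cc3)C(=O)Nc3cc(Cl)c(Cl)cc32)CC1` has chloro where compound 3 has tert-butyl. In this assay compound 1 reaches only the assay limit of > 10000 nM, a limit and not a number (the limit of > 10000 nM in this assay, at which 1 of the 3 values shown sits). Going by the values given here, the one measured step, an at least 6.8-fold lower number from compound 1 to compound 3 (0.83 log units; beyond the scatter), shows that the group at this position matters.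

Compound 4 `COc1ccc(C2(NC(=O)CN3CCN(C)CC3)C(=O)Nc3cc(Cl)c(Cl)cc32)cc1` differs from compound 3 in one place: methoxy in place of tert-butyl on an aromatic carbon. Among the compounds with values here, no measured step covers this exact exchange on the core of compound 3. The methoxy-bearing compound 2, on its own core, gives 525 nM. The chloro-bearing compound 1 gives only a limit. Compound 4 is therefore expected to show a step of a 1.8-fold lower number from compound 3 to compound 4 (0.26 log units; within the scatter) in this assay, toward a lower number. Compound 4 is estimated at 800 nM, with a range from 250 nM to 3000 nM.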

Compound 4, half-maximal inhibitory concentration: 700 nM
For compound 4 the middle estimate is 1.1-fold (0.06 log units) above the measured one; the range from low to high includes it.
By their numbers in this assay, from the lowest: compounds 2 and 4 (each within the scatter of the next); then compound 3. At a limit, above all of these: compound 1.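

In this assay, the exchange of 4-(tert-butyl)phenyl for 4-methoxyphenyl can now be read directly on a single core, and it gives a 2.1-fold lower number from compound 3 to compound 4 (0.32 log units; beyond the scatter), a modest step that places methoxy ahead of tert-butyl at this position. The other two steps separate the two parts of the structure: the change of methyl to chloro on the core gives a 1.3-fold higher number from compound 2 to compound 4 (0.12 log units; within the scatter), which cannot distinguish the two methoxy compounds, whereas the change at the phenyl position gives an at least 14-fold lower number from compound 1 to compound 4 (1.15 log units; beyond the scatter), the largest step shown, so in this series the group on the phenyl ring counts for more than this change on the core. The size of that large step remains open-ended, since compound 1 stands at a limit and not at a number: the limit of > 10000 nM in this assay, at which 1 of the 4 values shown sits.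

The compounds shown do not tell whether a longer ether such as ethoxy, a hydroxyl or an amine at this position would carry the number lower still. They also leave open whether the order of methoxy, tert-butyl and chloro would hold on the core of compound 2.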